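Replacing the Formyl Group of Compound 2

This account rests on a few compounds, and the source may have more. Where it says the series, first, only, none or still open, it means among the compounds named here.

Compound 1 `C=C[C@](C)(CCCC(C)C)CCc1ccc(O)cc1`: > 36600 nM
Compound 2 `C=C[C@@](C)(/C=C/c1ccc(O)cc1)CCC=O`: > 36600 nM
Compound 3 `C=C[C@@](C)(/C=C/c1ccc(O)cc1)CC/C=C/C(=O)OCc1ccccc1`: > 36600 nM

These three results come from a functional assay on SEM cells (Homo sapiens) for cytotoxicity, with a stated time of 72 h; a lower number here means that less compound is needed, a higher number that more compound is needed for the effect. Each is a limit of the assay, not a number, and together they show (the limit of > 36600 nM in this assay, at which 3 of the 3 values shown sit). Compound 2 therefore has no exact value to start from. Compound 4 `C=C[C@@](C)(/C=C/c1ccc(O)cc1)CC/C=C(\C)CO` differs from it as follows: 2-(hydroxymethyl)prop-1-en-1-yl in place of formyl on a saturated chain carbon, three bonds along the chain from two double-bonded chain carbons. Here 2-(hydroxymethyl)prop-1-en-1-yl takes the place of formyl on a saturated chain carbon. Among the measured compounds shown here, no measured pair differs in just one place, so the expectation in this assay is cautious: little change, or a modest shift to a lower number. The expected at least 1.2-fold lower number from compound 2 to compound 4 (0.08 log units; that floor lies within the scatter) is small. For compound 4 the estimated value is 30000 nM, within an expected range of 12000 nM to 60000 nM.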

Compound 4, half-maximal effective concentration: > 36600 nM
Compound 4: a limit, no number (the forecaster's own chance of this, stated with the estimate: 60%); at least 1.2-fold (0.08 log units) between middle value and limit.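

Compound 2 and compound 4 each give a limit rather than a number, so no step can be read between them: the limit of > 36600 nM in this assay, at which 4 of the 4 values shown sit.

The compounds shown leave open which change to the shared core, if any, would give a measurable value.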